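A few compounds are considered here, and "the series" means these few. Any claim that something is new, unique, unknown or untested is made for them only; others in the source may bear on it.

Compound 1 (`CC(C)CCn1nc(-c2cccs2)c(O)c(C2=NS(=O)(=O)c3cc(NS(=O)(=O)C4CC4)ccc3N2)c1=O`) at > 1000 nM (limit)
Compound 2 (`CC(C)CCn1nc(-c2cccs2)c(O)c(C2=NS(=O)(=O)c3cc(NS(=O)(=O)C(C)C)ccc3N2)c1=O`) at > 1000 nM (limit)

In an ADME assay on Huh-7 cells (Homo sapiens) for cytotoxicity, with a stated time of 72 h (a higher number here means that more compound is tolerated, a lower number that less compound is tolerated), compound 2 gives > 1000 nM as a limit and not a number. Compound 2 thus stands at the limit of > 1000 nM in this assay, at which 2 of the 2 values shown sit, and cannot be ranked against compound 1. Compound 3 (`CCCS(=O)(=O)Nc1ccc2c(c1)S(=O)(=O)N=C(c1c(O)c(-c3cccs3)nn(CCC(C)C)c1=O)N2`) carries propyl in place of isopropyl on a sulfonyl sulfur. Among the measured compounds shown here, the only measured step at this place is a step that the two limits leave unreadable from compound 1 to compound 2 and offers no size to carry over. No change beyond the scatter is expected, and the estimated step that the limit leaves unreadable from compound 2 to compound 3 reflects that. Compound 3 is estimated at 1500 nM with an expected range from 1000 nM to 5000 nM and will probably be reported only as a limit.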

Compound 3, half-maximal cytotoxic concentration: > 1000 nM
Compound 3 ended at the assay's limit (the forecaster's own chance of this, stated with the estimate: 85%); the middle value is on the limit's open side.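

No step can be read among compound 1, compound 2 and compound 3, as each gives only a limit: the limit of > 1000 nM in this assay, at which 3 of the 3 values shown sit.

The compounds shown leave open whether cyclopropyl, isopropyl and propyl on a sulfonyl sulfur differ at all in cytotoxicity.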